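From 3-chlorophenyl to 4-hydroxyphenyl on the amide nitrogen

A few compounds are considered here, and "the series" means these few. Any claim that something is new, unique, unknown or untested is made for them only; others in the source may bear on it.

Of the compounds shown here, three have been measured in a functional assay on OVCAR-5 cells (Homo sapiens) for inhibition, read by CCK-8 assay, with a stated time of 72 h, tested at 10 uM (on this read-out lower numbers stand for less inhibition of growth and higher numbers for more inhibition of growth at the one concentration tested), so far. Compound 2 `CN(C)C(=O)c1cc2cnc(Nc3ccc(NC(=O)C4(C(=O)Nc5cccc(Cl)c5)CC4)cc3)nc2n1C1CCCC1` stands highest with 88.1% while compound 1 `CN(C)C(=O)c1cc2cnc(Nc3ccc(N)cn3)nc2n1C1CCCC1` gives 68% and compound 3 `CN(C)C(=O)c1cc2cnc(Nc3ccc(NC(=O)C4(C(=O)Nc5ccc(F)cc5)CC4)cc3F)nc2n1C1CCCC1` gives 33%, both gaps lying beyond the scatter. Compound 4 `CN(C)C(=O)c1cc2cnc(Nc3ccc(NC(=O)C4(C(=O)Nc5ccc(O)cc5)CC4)cc3)nc2n1C1CCCC1` has 4-hydroxyphenyl in place of 3-chlorophenyl on an amide-type nitrogen. For the measured compounds named here, no measured pair isolates this change, so only the spread of values can guide the expectation. Compound 2 with 88.1% sits at the top of that spread, which leaves more room for a fall than for a rise. The expected change is a number 28.1 percentage points lower from compound 2 to compound 4 (beyond the scatter), a fall beyond the scatter. For compound 4 the estimated value is 60%, with 38% and 82% as the expected ends of the range.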

Compound 4, percent growth inhibition at one concentration: 90.9%
Compound 4: the middle estimate sits 30.9 percentage points below what was measured, outside the stated range (above it).
By their numbers in this assay, from the lowest: compound 3; then compound 1; then compounds 2 and 4 (each within the scatter of the next).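

In this assay the exchange of 3-chlorophenyl for 4-hydroxyphenyl on the amide-type nitrogen gives a number 2.8 percentage points higher from compound 2 to compound 4 (within the scatter) and so leaves the reading unmoved. This position therefore takes either aromatic ring, the one with chlorine and no hydrogen-bond donor or the one with a hydroxyl that adds a donor and an acceptor, and high growth inhibition is kept. Nothing on hand explains why the two compounds read alike.

Still open, as far as these compounds go, is whether 4-aminophenyl or 4-carboxyphenyl on this nitrogen would read the same. A saturated ring such as cyclohexyl in this place also remains an open case.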